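The source may hold more compounds than are shown below. What is called first, only, known or untested is meant among the compounds shown, and "the series" means these compounds.

Of the compounds shown here, three built on one shared core have been tested in a functional assay on A549 cells (Homo sapiens) for antiproliferative activity, read by MTT assay, with a stated time of 48 h; a lower number here means a stronger inhibitor, a higher number a weaker inhibitor. Compound 1 `N#CC1=C(N)Oc2c(N)cc3nc4ccccc4nc3c2C12C(=O)N(Cc1cnnn1-c1ccc(F)cc1)c1ccccc12` reaches only a limit of the assay, > 50000 nM. Compound 2 `N#CC1=C(N)Oc2c(N)cc3nc4ccccc4nc3c2C12C(=O)N(Cc1cnnn1-c1cccc(Br)c1)c1ccccc12` gives 18900 nM. Compound 3 `COc1ccc(-n2nncc2CN2C(=O)C3(C(C#N)=C(N)Oc4c(N)cc5nc6ccccc6nc5c43)c3ccccc32)cc1` also reaches only a limit, > 50000 nM. Compound 3 therefore stands at the point where the assay stops counting (the limit of > 50000 nM in this assay, at which 2 of the 3 values shown sit), together with compound 1. The step of an at least 2.6-fold higher number from compound 2 to compound 3 (0.42 log units; beyond the scatter) marks the 4-methoxyphenyl as the weaker choice, while the step that the two limits leave unreadable from compound 1 to compound 3 has no readable size. Compound 4 `CCc1cccc(C)c1-n1nncc1CN1C(=O)C2(C(C#N)=C(N)Oc3c(N)cc4nc5ccccc5nc4c32)c2ccccc21` carries the change (2-ethyl-6-methylphenyl in place of 4-methoxyphenyl on an aromatic nitrogen). Among the measured compounds shown here, no measured step matches this change, so the expectation leans on compound 2 and its value 18900 nM. Compound 4 is expected near 35000 nM, within 12000 nM to 100000 nM. That amounts to an estimated step of an at least 1.4-fold lower number from compound 3 to compound 4 (0.15 log units; that floor lies within the scatter) in this assay.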

Compound 4, half-maximal inhibitory concentration: > 50000 nM
Compound 4 gave a limit, no number; the forecaster's own chance of this, stated with the estimate: 55%; at least 1.4-fold (0.15 log units) between middle value and limit.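

The step of an at least 2.6-fold higher number from compound 2 to compound 4 (0.42 log units; beyond the scatter) shows that a 2-ethyl-6-methylphenyl group on this aromatic nitrogen, like 4-methoxyphenyl, does worse than 3-bromophenyl. The steps among compound 1, compound 3 and compound 4 cannot be read, because all three sit at one limit: the limit of > 50000 nM in this assay, at which 3 of the 4 values shown sit.

Among these four compounds, only compound 2 gives a number, so changing this group has so far moved the result in just one case. As far as these compounds go, whether a phenyl ring carrying a chlorine or an amine would also give a number stays open.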